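Cyclohexylamine analogue of a curcumin-type enaminone: expected activity

This account rests on a few compounds, and the source may have more. Where it says the series, first, only, none or still open, it means among the compounds named here.

Of the compounds shown here, three sharing one core have been measured in a functional assay on EA.hy 926 cells (Homo sapiens), read by fluorescence, tested at 1 uM; a lower number here means a weaker effect, a higher number a stronger effect of the compound at the concentration tested. Compound 1 `C=CCNC(=C\C(=O)/C=C/c1ccc(O)c(OC)c1)/C=C/c1ccc(O)c(OC)c1` gives 124%, the highest of the three numbers. Going by the values given here, compound 2 `CCC(C)NC(=C\C(=O)/C=C/c1ccc(O)cc1)/C=C/c1ccc(O)cc1` gives 99%, and compound 3 `CC(C)CNC(=C\C(=O)/C=C/c1ccc(O)cc1)/C=C/c1ccc(O)cc1` gives 100%; both stand beyond the usual scatter below compound 1, and the only single-point step among them, a number 1 percentage points higher from compound 2 to compound 3 (within the scatter), lies within the scatter.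

The compound to be measured next is compound 4 `COc1cc(/C=C/C(=O)/C=C(/C=C/c2ccc(O)c(OC)c2)NC2CCCCC2)ccc1O`. It differs from compound 1 in one place: cyclohexyl in place of allyl on an amine nitrogen. Among the compounds with values here, only one measured step touches the group on the amine nitrogen, the exchange from compound 2 to compound 3, and that step changed the read-out by an amount inside the scatter. Within the data shown here, both compounds of that step carry arms without the methoxy group of compound 1 and compound 4, so the comparison is indirect, and no measured step shows how a ring in place of an open chain on that nitrogen behaves.

On this basis compound 4 is expected to stay close to compound 1, with an estimated step of a number 4 percentage points lower from compound 1 to compound 4 (within the scatter) in this assay. The estimate for compound 4 is 120%, expected to fall between 100% and 140%.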

Compound 4, a percentage reported as activity, at one concentration (the size of the read-out at that concentration, not a potency): 91%
For compound 4 the middle estimate is 29 percentage points above the measured one; the measured number lies below the stated range.
By their numbers in this assay, from the lowest: compounds 4, 2 and 3 (each within the scatter of the next); then compound 1.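

Cyclohexyl in place of allyl on an amine nitrogen gives a number 33 percentage points lower from compound 1 to compound 4 (beyond the scatter) in this assay, so the group at this position can shift the read-out well past the scatter, whereas the one earlier change there, a number 1 percentage points higher from compound 2 to compound 3 (within the scatter), showed no such effect. That earlier change swapped one open chain for another, while this one replaces an open chain carrying a double bond with a six-membered carbon ring; neither group has hydrogen-bond donors or acceptors or a net charge, so the listed differences are size, the ring and the double bond. No measurement available here explains why the number falls.

Which of these differences accounts for the step stays open: an n-propyl group would keep the open chain without the double bond, and a cyclopropyl group would bring in a ring of much smaller size. From the compounds shown here alone, it is also open whether the step would carry over to arms without the methoxy group, for which a cyclohexyl group on the core of compound 2 would give a direct comparison.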